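This account rests on a few compounds, and the source may have more. Where it says the series, first, only, none or still open, it means among the compounds named here.

Compound 1 `COCCOCn1cc(C#N)c2c(N)ncnc21` gives > 100000 nM in a functional assay on KB cells (Homo sapiens) for cytotoxicity (a higher number here means a weaker inhibitor, a lower number a stronger inhibitor), which is a limit of the measurement rather than a number.
Compound 2 `N#Cc1cn(COCc2ccccc2)c2ncnc(N)c12` gives > 100000 nM, again a limit.
Compound 3 `COCCOCn1cc(C(N)=S)c2c(N)ncnc21` gives 183000 nM.

Compound 1 therefore stands at a limit of this assay and not at a measured number, and (the limit of > 100000 nM in this assay, at which 2 of the 3 values shown sit). The two measured steps that start from compound 1 are both unreadable. In the step that the two limits leave unreadable from compound 1 to compound 2 both ends are limits, and no size can be read. In the step that the limit leaves unreadable from compound 1 to compound 3 the starting point is a limit, and no size can be read.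

Compound 4 `CCCn1cc(C#N)c2c(N)ncnc21` differs from compound 1 by ethyl in place of 2-methoxyethoxy on a saturated chain carbon bound to an aromatic nitrogen. Both measured steps bear on it only in that they start from the same limit at compound 1, and neither gives a readable size or direction, so the account can expect no step beyond the scatter and, most likely, another limit. Compound 4 is estimated at 150000 nM, with a range from 50000 nM to 500000 nM, which means an expected step that the limit leaves unreadable from compound 1 to compound 4.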

Compound 4, half-maximal inhibitory concentration: > 100000 nM
Compound 4: only a limit was reported (the forecaster's own chance of this, stated with the estimate: 80%); the middle value is on the limit's open side.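

Compound 1 and compound 4 both stand only at a limit in this assay, so no step can be read between them: the limit of > 100000 nM in this assay, at which 3 of the 4 values shown sit. The compounds shown leave open whether ethyl in place of 2-methoxyethoxy changes the result in this assay at all, and in which direction.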